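Swapping a Hydroxyethyl for Isobutyl on a Sulfonamide

This account rests on a few compounds, and the source may have more. Where it says the series, first, only, none or still open, it means among the compounds named here.

Measured compounds and their numbers:
compound 1 `CC[C@@H]1C(=O)N(C)c2cnc(Nc3ccc(S(=O)(=O)NC)cc3)nc2N1C1CCCC1` gives 3.4 nM
compound 2 `CC[C@@H]1C(=O)N(C)c2cnc(Nc3ccc(S(=O)(=O)NC4CCCC4)cc3)nc2N1C1CCCC1` gives 23.9 nM
compound 3 `CC[C@@H]1C(=O)N(C)c2cnc(Nc3ccc(S(=O)(=O)NCCO)cc3)nc2N1C1CCCC1` gives 7.86 nM

All three share one core and differ only in the group on a sulfonamide nitrogen. In an assay for inhibition of serine/threonine-protein kinase PLK2 (Homo sapiens), read by FRET and Z'-LYTE, with a stated time of 1 h (on this read-out lower numbers stand for stronger inhibition and higher numbers for weaker inhibition), compound 3 stands second highest of the three numbers: a 2.3-fold higher number from compound 1 to compound 3 (0.36 log units; beyond the scatter), and a 3.0-fold lower number from compound 2 to compound 3 (0.48 log units; beyond the scatter), so compound 3 sits between the other two and clear of both.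

Compound 4 `CC[C@@H]1C(=O)N(C)c2cnc(Nc3ccc(S(=O)(=O)NCC(C)C)cc3)nc2N1C1CCCC1` is not yet measured. It differs from compound 3 by isopropyl in place of hydroxymethyl on a saturated chain carbon bound to a sulfonamide nitrogen. For the measured compounds named here, two measured steps bear on this. The step of a 7.0-fold higher number from compound 1 to compound 2 (0.85 log units; beyond the scatter) shows that a larger hydrocarbon group on the sulfonamide nitrogen raised the number. The step of a 3.0-fold lower number from compound 2 to compound 3 (0.48 log units; beyond the scatter) shows that replacing such a group with a hydroxyl-bearing chain lowered it. Compound 4 moves toward a hydrocarbon group again, smaller than cyclopentyl, so a modest rise in this assay is expected. For compound 4 the expected value is 15 nM, with a range from 6 nM to 40 nM. This estimate means a 1.9-fold higher number from compound 3 to compound 4 (0.28 log units; within the scatter).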

Compound 4, half-maximal inhibitory concentration: 21.8 nM
For compound 4 the middle estimate is 1.5-fold (0.16 log units) below the measured one; the range from low to high includes it.
By their numbers in this assay, from the lowest: compound 1; then compound 3; then compounds 4 and 2 (each within the scatter of the next).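

Compound 2 and compound 3 differed in both a ring and a hydroxyl, so their step could not separate the two changes. Neither group in the new pair has a ring, and the change from 2-hydroxyethyl to isobutyl still raises the number (a 2.8-fold higher number from compound 3 to compound 4 (0.44 log units; beyond the scatter)), so the hydroxyl-bearing chain is tied to a lower number even without a ring in the comparison. The open isobutyl chain and the cyclopentyl ring give matching results (a 1.1-fold lower number from compound 2 to compound 4 (0.04 log units; within the scatter)), yet the small methyl group of compound 1 stays clearly ahead of isobutyl (a 6.4-fold higher number from compound 1 to compound 4 (0.81 log units; beyond the scatter)), and no measurement here explains why.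

The compounds shown leave open whether a 2-methoxyethyl or 2-aminoethyl group would behave like 2-hydroxyethyl. They also leave open where a plain ethyl group would fall relative to methyl and isobutyl.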